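Phenyl for isopropyl on the hydroxylated chain

A few compounds are considered here, and "the series" means these few. Any claim that something is new, unique, unknown or untested is made for them only; others in the source may bear on it.

This account follows one step in a small series of sulfonamides bearing a shared core of compound 1, `CC(C)c1ccccc1OCCCN1CCC(NS(=O)(=O)c2ccc(F)cc2)CC1`. In an assay on HEK293 cells for displacement of a labelled ligand from 5-hydroxytryptamine receptor 7 (Homo sapiens), read by scintillation counting, with a stated time of 1 h (a higher number here means a weaker inhibitor, a lower number a stronger inhibitor), compound 1 gives 32 nM. Compound 2, `O=S(=O)(NC1CCN(CCCOc2ccccc2-c2ccccc2)CC1)c1ccc(F)cc1`, gives 58 nM in this assay, and compound 3, `CC(C)c1ccccc1OCC(O)CN1CCC(NS(=O)(=O)c2ccc(F)cc2)CC1`, gives 104 nM. Compound 3 therefore shows the highest number of the three: it is a 3.3-fold higher number from compound 1 to compound 3 (0.51 log units; beyond the scatter) away from compound 1, while compound 2 and compound 3 differ from each other only within the scatter.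

Compound 4, `O=S(=O)(NC1CCN(CC(O)COc2ccccc2-c2ccccc2)CC1)c1ccc(F)cc1`, is not yet measured. Relative to compound 3 the change is phenyl in place of isopropyl on an aromatic carbon. The same exchange has been seen once, between compound 1 and compound 2, where it produced a 1.8-fold higher number from compound 1 to compound 2 (0.26 log units; within the scatter). Among the measured compounds shown here, on that single precedent the step from compound 3 to compound 4 is expected to be small, at most a slight rise in the number, and most likely not beyond the scatter; compound 3 is the only hydroxylated example, so there is no second measurement to confirm that the exchange behaves the same on this chain.

Compound 4 is thus estimated at 150 nM in this assay, within a range of 70 nM to 350 nM. This corresponds to an expected step of a 1.4-fold higher number from compound 3 to compound 4 (0.16 log units; within the scatter).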

Compound 4, inhibition constant: 59 nM
For compound 4 the middle estimate is 2.5-fold (0.41 log units) above the measured one, outside the stated range (below it).
By their numbers in this assay, from the lowest: compounds 1, 2, 4 and 3 (each within the scatter of the next, the first and the last beyond it).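

The exchange of phenyl for isopropyl on an aromatic carbon, now read on the hydroxylated chain in this assay, gives a 1.8-fold lower number from compound 3 to compound 4 (0.25 log units; within the scatter), and this reading does not agree with the one on the unsubstituted chain: the same change on two cores in this assay, a 1.8-fold higher number (0.26 log units; within the scatter) from compound 1 to compound 2 and a 1.8-fold lower number (0.25 log units; within the scatter) from compound 3 to compound 4, 3.2-fold (0.50 log units) apart, beyond the scatter of two such steps. The hydroxy exchange, now read with phenyl on the aromatic carbon, gives a 1.0-fold higher number from compound 2 to compound 4 (0.01 log units; within the scatter), and it likewise differs from its reading with isopropyl there: the same change on two cores in this assay, a 3.3-fold higher number (0.51 log units; beyond the scatter) from compound 1 to compound 3 and a 1.0-fold higher number (0.01 log units; within the scatter) from compound 2 to compound 4, 3.2-fold (0.50 log units) apart, beyond the scatter of two such steps. Among the compounds shown here, the two changes therefore do not add independently in these four compounds, since hydroxy in place of hydrogen on the chain gives a step beyond the scatter with isopropyl but one within the scatter with phenyl, something no single step among the earlier compounds could show.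

As far as these compounds go, these four compounds form only one such set, so it remains open whether the same dependence holds with another group on this aromatic carbon, such as methoxy or chloro, or with a longer chain or an amine in place of the hydroxy on the chain. They also give no account of why the two changes depend on each other, and each of the gaps rests on single measurements.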